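Halogenated benzyl replacements for pyrrolidin-3-yl at the ring nitrogen

The compounds below may be only part of what the source reports. "The series", "measured", "known", "first", "only" and "open" are said of these compounds alone.

Compound 1 `Cc1cc(Nc2nc(NC3CCNC3)nc3[nH]ncc23)n[nH]1` gives the middle of the three numbers in an assay on isolated protein for inhibition of serine/threonine-protein kinase PAK 4 (Homo sapiens), read by HTRF, with a stated time of 60 min (a higher number here means a weaker inhibitor, a lower number a stronger inhibitor), at 1050 nM; compound 3 `Cc1cc(Nc2nc(NCc3cccc(Cl)c3)nc3[nH]ncc23)n[nH]1` at 611 nM and compound 2 `Cc1cc(Nc2nc(NCc3ccccc3)nc3[nH]ncc23)n[nH]1` at 1960 nM both sit within the scatter of it, the steps being a 1.7-fold lower number from compound 1 to compound 3 (0.24 log units; within the scatter) and a 1.9-fold higher number from compound 1 to compound 2 (0.27 log units; within the scatter). Compound 4 `Cc1cc(Nc2nc(NCc3ccc(F)cc3)nc3[nH]ncc23)n[nH]1` carries the change (4-fluorobenzyl in place of pyrrolidin-3-yl on a nitrogen on an aromatic ring). The bearing steps are the two benzyl replacements from compound 1, neither beyond the scatter, and a 3.2-fold lower number from compound 2 to compound 3 (0.51 log units; beyond the scatter), which shows that a halogen on the benzyl ring can move the number. Going by the values given here, a 4-fluorobenzyl has no measured counterpart, so no step beyond the scatter is expected in this assay; compound 4 is estimated at 1100 nM, within 450 nM to 2700 nM, an expected step of a 1.0-fold higher number from compound 1 to compound 4 (0.02 log units; within the scatter).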

Compound 4, half-maximal inhibitory concentration: 395 nM
For compound 4 the middle estimate is 2.8-fold (0.44 log units) above the measured one; measured number outside the range, below it.
By their numbers in this assay, from the lowest: compounds 4, 3, 1 and 2 (each within the scatter of the next, the first and the last beyond it).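

In this assay the 4-fluorobenzyl takes the replacement of pyrrolidin-3-yl at this nitrogen beyond the scatter (a 2.7-fold lower number from compound 1 to compound 4 (0.42 log units; beyond the scatter)). Fluoro in place of hydrogen on the benzyl ring also moves the number beyond the scatter (a 5.0-fold lower number from compound 2 to compound 4 (0.70 log units; beyond the scatter)), so this effect, seen first with the chloro of compound 3, is not confined to chloro. The two halogenated benzyls remain unseparated (a 1.5-fold lower number from compound 3 to compound 4 (0.19 log units; within the scatter)).

Open, from the compounds shown here alone, is whether a methoxy or an amine on the benzyl ring, or a phenethyl chain, would hold these numbers. No evidence available here bears on why the numbers move.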